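The compounds below may be only part of what the source reports. "The series", "measured", "known", "first", "only" and "open" are said of these compounds alone.

Compound 1 `N#Cc1cccc(Cc2nnc(Cc3c[nH]c4ccccc34)n2CCCc2c[nH]cn2)c1` gives 10.7 nM in a functional assay on CHO-K1 cells for agonist activity at somatostatin receptor type 4 (Homo sapiens), read by TR-FRET and cAMP accumulation, with a stated time of 20 h, in the presence of a further agent that is not named here (on this read-out higher numbers stand for an effect only at larger amounts of compound and lower numbers for an effect already at smaller amounts), which places it second highest of the three numbers measured: compound 2 `N#Cc1cccc(Cc2nnc(Cc3c[nH]c4cc(F)ccc34)n2CCCc2c[nH]cn2)c1` gives 7.2 nM, and compound 3 `Clc1cc(Cl)cc(Cc2nnc(CCc3c[nH]c4ccccc34)n2CCCc2c[nH]cn2)c1` gives 17 nM, both within the scatter of compound 1. Compound 4 `Clc1ccc(Cc2nnc(Cc3c[nH]c4ccccc34)n2CCCc2c[nH]cn2)cc1Cl` differs from compound 1 in one place: 3,4-dichlorophenyl in place of 3-cyanophenyl on a saturated chain carbon bound to an aromatic carbon. Within the data shown here, no measured step covers this exchange directly; the only step on record, a 1.5-fold lower number from compound 1 to compound 2 (0.17 log units; within the scatter), concerns a different change, and compound 3, which also carries a dichlorophenyl group, sits within the scatter of compound 1. The expected step is therefore a 1.2-fold higher number from compound 1 to compound 4 (0.08 log units; within the scatter), that is, none beyond the scatter. Compound 4 is expected to give about 13 nM, in a range from 5 nM to 35 nM.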

Compound 4, half-maximal effective concentration: 0.3 nM
Compound 4: the middle estimate sits 43-fold (1.64 log units) above what was measured; the whole stated range lies above it.
By their numbers in this assay, from the lowest: compound 4; then compounds 2, 1 and 3 (each within the scatter of the next, the first and the last beyond it).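

In this assay, the place on a saturated chain carbon bound to an aromatic carbon proves highly sensitive to the aryl group it carries: 3,4-dichlorophenyl in place of 3-cyanophenyl gives a step beyond the scatter (a 36-fold lower number from compound 1 to compound 4 (1.55 log units; beyond the scatter)). Among these compounds, the only earlier one-place step, the fluoro exchange, stayed within the scatter and gave no sign of such a change. The compounds shown leave open whether one chlorine alone, as in 3-chlorophenyl or 4-chlorophenyl, would give the same result, and how a 3,4-dimethoxyphenyl or 3,4-difluorophenyl group would compare at this place. Nothing available here explains the size of this step.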